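Halogen swap on the phenyl ring of compound 4

The compounds below may be only part of what the source reports. "The series", "measured", "known", "first", "only" and "open" are said of these compounds alone.

Compound 1, `OC(CCn1nc2c(Br)c(Br)c(Br)c(Br)c2n1)c1cccc(Br)c1`, gives 106% in a functional assay on MCF7 cells (Homo sapiens) for antiproliferative activity, read by MTT assay, with a stated time of 48 h, tested at 25 uM; a higher number here means a weaker effect of the compound at the concentration tested, a lower number a stronger effect.
Compound 2, `OC(CCn1nc2c(Br)c(Br)c(Br)c(Br)c2n1)c1ccc(F)cc1`, gives 97% in this assay.
Compound 3, `OC(CCn1nc2c(Br)c(Br)c(Br)c(Br)c2n1)c1cccc(Cl)c1`, gives 101% in this assay.

All three share the same core and differ only in the phenyl ring attached to the carbon bearing the hydroxyl. In this assay compound 3 stands second highest of the three numbers, nearest to compound 2 and furthest from compound 1, yet both gaps lie within the scatter, so the three compounds cannot be told apart on these data.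

Compound 4, `OC(CCn1nc2c(Br)c(Br)c(Br)c(Br)c2n1)c1ccc(Br)cc1`, is not yet measured. It differs from compound 3 in one place: 4-bromophenyl in place of 3-chlorophenyl on a saturated chain carbon bound to an oxygen on a saturated carbon and a saturated chain carbon.

The measured steps that touch this ring all stayed within the scatter: a number 9 percentage points lower from compound 1 to compound 2 (within the scatter), a number 4 percentage points higher from compound 2 to compound 3 (within the scatter) and a number 5 percentage points lower from compound 1 to compound 3 (within the scatter). Changing which halogen sits on the phenyl ring, or where it sits, has so far not moved the read-out beyond the noise. A step of similar size, that is none beyond the scatter, is therefore expected in this assay from compound 3 to compound 4, namely a number 1 percentage points lower from compound 3 to compound 4 (within the scatter).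

Compound 4 is estimated to give 100%, within a range from 88% to 112%.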

Compound 4, a percentage reported as activity, at one concentration (the size of the read-out at that concentration, not a potency): 105%
For compound 4 the middle estimate is 5 percentage points below the measured one, within the range that was stated.
By their numbers in this assay, from the lowest: compounds 2, 3, 4 and 1 (each within the scatter of the next).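

In this assay, for the compounds shown here, compound 4 gives the first pair in which only the place of the halogen changes: 4-bromophenyl in place of 3-bromophenyl gives a number 1 percentage points lower from compound 1 to compound 4 (within the scatter) and stays inside the usual noise. It also gives a halogen swap at this second ring position, since bromo in place of fluoro gives a number 8 percentage points higher from compound 2 to compound 4 (within the scatter), while changing the halogen and its place together gives a number 4 percentage points higher from compound 3 to compound 4 (within the scatter), and neither step can be told from repeat-measurement noise. No measurement here offers an explanation for this flat result.

These four compounds therefore cover only halogens on the phenyl ring, and they do not show whether a non-halogen group there, such as an amine, a methoxy group or a carboxylic acid, would move the read-out beyond the scatter. Also open, from the compounds shown here alone, is what happens when the change lies elsewhere, for example if the hydroxyl becomes a carbonyl, if the saturated chain is made longer, or if the bromo groups on the shared core are replaced by hydrogen.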